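Chloro in Place of Amino: Weak Cytotoxicity Expected

The source may report more compounds than this note shows. Statements on the series, on what has been measured and on what is new or still open speak of the compounds shown alone.

Compound 1 `Nc1nc(Cl)c2ncn(Cc3ccccc3CCl)c2n1` was tested in a functional assay on K562 cells (Homo sapiens) for cytotoxicity, read by sulforhodamine B assay, with a stated time of 48 h; on this read-out lower numbers stand for higher toxicity in this test and higher numbers for lower toxicity in this test. In this assay compound 1 reaches only a limit of the test, > 100000 nM, and no number. Compound 2 `Nc1nc(Cl)c2ncn(Cc3ccc(CCl)cc3)c2n1` likewise stops at a limit in this assay, > 100000 nM. Compound 3 `ClCc1ccccc1Cn1cnc2ncnc(Cl)c21` gives a measured value in this assay, 83200 nM. Two of the three values thus sit at the limit of > 100000 nM in this assay, at which 2 of the 3 values shown sit, and compound 1 stands there, showing no toxicity within the range tested.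

Compound 4 `ClCc1ccccc1Cn1cnc2c(Cl)nc(Cl)nc21` differs from compound 1 by chloro in place of amino on an aromatic carbon. Within the data shown here, no measured pair shows this change, so the size of the step is open. Since compound 3, which also lacks the amino, gives 83200 nM, only a modest shift toward toxicity is expected, within or barely beyond the scatter, as the expected step of an at least 1.6-fold lower number from compound 1 to compound 4 (0.22 log units; that floor lies within the scatter) states. For compound 4 the estimate in this assay is 60000 nM, expected between 20000 nM and 150000 nM.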

Compound 4, concentration lethal to 50% of the cells: 910 nM
The estimate for compound 4 lay 66-fold (1.82 log units) above the measured number; the whole stated range lies above it.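

In this assay, chloro in place of amino on this aromatic carbon, between two ring nitrogen atoms, gives an at least 100-fold lower number from compound 1 to compound 4 (2.04 log units; beyond the scatter). Compound 3, which has neither group at this position, gives 83200 nM, whereas compound 4 gives 910 nM, so the high toxicity in this test goes with the chloro itself and not merely with losing the amino. The real step may be larger, since compound 1 reaches only a limit of the test: the limit of > 100000 nM in this assay, at which 2 of the 4 values shown sit.

On these data alone, whether another group at this position, such as bromo or methoxy, would match chloro remains open.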